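Bromo in Place of Hydrogen on the Shared Core

The source may hold more compounds than are shown below. What is called first, only, known or untested is meant among the compounds shown, and "the series" means these compounds.

Measured so far in an ADME assay on microsomes from liver (Rattus norvegicus, strain Wistar) for metabolic stability, tested at 2.5 uM; a lower number here means slower removal, a higher number faster removal of the compound:
compound 1 `Fc1cc(Cl)ccc1-c1ccc(Cn2nnc3ccccc32)cn1` — 0.8 mL/min/g
compound 2 `Fc1ccc2nnn(Cc3ccc(-c4ccc(Cl)cc4F)nc3)c2c1` — 1 mL/min/g

Compound 1 stands lowest of the two numbers in this assay; its nearest neighbour is compound 2, and the step of a 1.3-fold higher number from compound 1 to compound 2 (0.10 log units; within the scatter) lies within the scatter, so the two compounds are not separated on this read-out.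

Compound 3 `Fc1cc(Cl)ccc1-c1ccc(Cn2nnc3c(Br)cccc32)cn1` is not yet measured. It differs from compound 1 by bromo in place of hydrogen on an aromatic carbon.

Within the data shown here, the only measured step, a 1.3-fold higher number from compound 1 to compound 2 (0.10 log units; within the scatter), is a different halogen entering at a different place on the shared core, and it changed nothing beyond the scatter. It bears on the present change only as a halogen for a hydrogen on an aromatic carbon. Among the measured compounds shown here, no measured step speaks for a shift beyond the scatter in this assay in either direction, so none is expected.

Compound 3 is therefore estimated at 1 mL/min/g, with a range of 0.5 mL/min/g to 2 mL/min/g, which means an expected step of a 1.3-fold higher number from compound 1 to compound 3 (0.10 log units; within the scatter).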

Compound 3, intrinsic clearance in a liver preparation (reported as CLH), per the amount of preparation that the assay uses: 0.4 mL/min/g
Beside the measured number, compound 3's estimate is 2.5-fold (0.40 log units) above it; measured number below the stated range.
By their numbers in this assay, from the lowest: compounds 3, 1 and 2 (each within the scatter of the next, the first and the last beyond it).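

In this assay, bromo in place of hydrogen on an aromatic carbon, ortho to a fused ring and meta to a fused ring, gives a 2.0-fold lower number from compound 1 to compound 3 (0.30 log units; within the scatter) and so leaves compound 3 not separated from compound 1 on this read-out. Among these compounds, this position therefore takes a bromo, a single heavy atom, without a shift beyond the scatter, as the fluoro change elsewhere on the shared core did with a 1.3-fold higher number from compound 1 to compound 2 (0.10 log units; within the scatter) in the only other step. Nothing available bears on why this number stands where it does.

Going by these compounds, whether this position behaves the same with a group other than a halogen, such as an amine, a carboxylic acid or a longer chain, remains open. So does the reading for bromo at the place that fluoro holds in compound 2.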